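The compounds below may be only part of what the source reports. "The series", "measured", "known", "first", "only" and "open" are said of these compounds alone.

Measured in a functional assay on VCaP cells (Homo sapiens) for antiproliferative activity, read by CCK-8 assay, with a stated time of 6 days; on this read-out higher numbers stand for weaker inhibition and lower numbers for stronger inhibition:
Compound 1 `CCN(c1cccc(-c2ccccc2)c1)c1ccc(C#N)c(Cl)c1`: "not determined" (no result reported)
Compound 2 `CCN(c1ccc(C#N)c(Cl)c1)c1cc(-c2cnc3ccccc3c2)ccc1C`: 25300 nM
Compound 3 `CCN(c1ccc(C#N)c(Cl)c1)c1cc(-c2ccnn2C)ccc1C`: 1670 nM

Only two of these compounds have a number, since no result was reported for compound 1. Of those two, compound 3 stands lower, at 1670 nM, and so shows the stronger inhibition. Its gap to compound 2, at 25300 nM, lies beyond the usual scatter of repeated measurements.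

The next compound is compound 4 `CCN(c1ccc(C#N)c(Cl)c1)c1cc(-c2cccnc2)ccc1C`, which carries pyridin-3-yl in place of 1-methyl-1H-pyrazol-5-yl on an aromatic carbon. The change sits on a six-membered aromatic ring of carbon only, para to a methyl group. Going by the values given here, no measured pair isolates a change of this kind, so the expectation rests on little. Among the compounds with values here, the only other number, from compound 2 at 25300 nM, is higher than that of compound 3, which leans the expectation upward rather than downward in this assay. The estimated change is modest, towards weaker inhibition and near the edge of the scatter: a 2.1-fold higher number from compound 3 to compound 4 (0.32 log units; beyond the scatter). For compound 4 the expected value is 3500 nM, with an estimated range from 1100 nM to 11000 nM.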

Compound 4, half-maximal inhibitory concentration: 1270 nM
The estimate for compound 4 lay 2.8-fold (0.44 log units) above the measured number; the range from low to high includes it.
By their numbers in this assay, from the lowest: compounds 4 and 3 (each within the scatter of the next); then compound 2.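

In this assay, going by these compounds alone, replacing 1-methyl-1H-pyrazol-5-yl with pyridin-3-yl on this aromatic carbon, para to a methyl group, gives a 1.3-fold lower number from compound 3 to compound 4 (0.12 log units; within the scatter), the first step that can be read. It shows that, at this position, a five-membered aromatic ring with 2 hetero atoms and a six-membered aromatic ring with 1 hetero atom cannot be told apart on this read-out, while compound 2, which differs from both at the same place, stands at 25300 nM. Nothing measured in this set offers an explanation for why the two groups read alike.

From the compounds shown here alone, what remains open is whether this level depends on where the ring nitrogen sits, as pyridin-2-yl and pyridin-4-yl at the same carbon would show, and whether an aromatic ring is needed here at all. A morpholine, a dimethylamino group or a carboxylic acid on this carbon would test that second point, and the compounds shown give no indication of how any of them would read in this assay.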